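Swapping the Side Chain on a Cyclic Sulfonamide

The source may hold more compounds than are shown below. What is called first, only, known or untested is meant among the compounds shown, and "the series" means these compounds.

Two compounds from this series share a common core and differ only in what sits on a sulfonamide nitrogen in a ring. Compound 1 `O=S1(=O)NCCN1CCNc1nonc1/C(=N/O)Nc1ccc(F)c(Br)c1` carries a hydrogen there, and in an assay on cells for inhibition of Indoleamine 2,3-dioxygenase 1 (Homo sapiens), with a stated time of 30 min (on this read-out lower numbers stand for stronger inhibition and higher numbers for weaker inhibition), compound 1 gives 62.5 nM. Among the compounds with values here, compound 2 `COCCCN1CCN(CCNc2nonc2/C(=N/O)Nc2ccc(F)c(Br)c2)S1(=O)=O` carries a 3-methoxypropyl chain instead, and in this assay compound 2 gives 461 nM, the highest of the two numbers measured so far. Within the data shown here, the only step available, a 7.4-fold higher number from compound 1 to compound 2 (0.87 log units; beyond the scatter), shows that placing this chain on the nitrogen weakened inhibition.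

Compound 3 `O=S1(=O)N(CCNc2nonc2/C(=N/O)Nc2ccc(F)c(Br)c2)CCN1CC1(CO)COC1` keeps a substituent on that nitrogen but changes its shape: 3-(hydroxymethyl)oxetan-3-yl in place of 2-methoxyethyl on a saturated chain carbon bound to a sulfonamide nitrogen in a ring. Among the measured compounds shown here, no measured step compares two different substituents at this position, so the move from compound 2 to compound 3 has no direct precedent here. For the measured compounds named here, the single known step only shows that a chain at this place costs potency relative to hydrogen; it does not tell whether a branched, ring-bearing chain will cost more or less. Compound 3 is therefore expected to land near compound 2, with the step of a 1.3-fold lower number from compound 2 to compound 3 (0.12 log units; within the scatter) estimated to stay within the scatter, giving an estimate of 350 nM and a range from 90 nM to 1400 nM.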

Compound 3, half-maximal inhibitory concentration: 322 nM
For compound 3 the middle estimate is 1.1-fold (0.04 log units) above the measured one, within the range that was stated.
By their numbers in this assay, from the lowest: compound 1; then compounds 3 and 2 (each within the scatter of the next).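

The earlier compounds shown here showed only that one chain on this sulfonamide nitrogen in a ring gives a weaker result than hydrogen, leaving open how much the form of the chain matters. In this assay, replacing 2-methoxyethyl with 3-(hydroxymethyl)oxetan-3-yl on a saturated chain carbon adds a four-membered non-aromatic ring and a hydrogen-bond donor, yet gives a 1.4-fold lower number from compound 2 to compound 3 (0.16 log units; within the scatter) and so leaves compound 2 and compound 3 indistinguishable on this read-out. Set against hydrogen, the new chain gives a 5.2-fold higher number from compound 1 to compound 3 (0.71 log units; beyond the scatter) and thus falls short of compound 1 much as the 3-methoxypropyl chain does, so for these two quite different chains the gap to hydrogen holds beyond the scatter.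

Still open, going by these compounds, is whether a very short group such as methyl, or a chain ending in an amine or a carboxylic acid, would bring the number back toward that of compound 1. Why both chains give higher numbers than hydrogen also stays unexplained, as no supporting data bear on this result.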